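The source may hold more compounds than are shown below. What is called first, only, known or untested is meant among the compounds shown, and "the series" means these compounds.

Working notes on the series

Compound 1 `CC(=O)c1cc(-c2ccccc2)cc2cc(-c3ccccc3)[nH]c12` and compound 2 `CC(=O)c1cc(/C=C/c2ccccc2)cc2cc(-c3ccccc3)[nH]c12` share one core and differ only at one aromatic carbon. In a functional assay on MCF7 cells (Homo sapiens) for cytotoxicity, read by MTT assay, with a stated time of 2 days, tested at 1 uM (on this read-out lower numbers stand for a stronger effect and higher numbers for a weaker effect at the one concentration tested), compound 1 gives 98.6%. In the same assay compound 2 gives 93.4%. Among the measured compounds shown here, the step between them, a number 5.2 percentage points lower from compound 1 to compound 2 (within the scatter), arises from 2-phenylethenyl in place of phenyl on an aromatic carbon and lies within the scatter, so the two compounds stand on a par in this assay; compound 2 is the second of only two numbers, and its nearest neighbour, compound 1, sits within the scatter of it.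

Compound 3 `CC(=O)c1cc(/C=C/c2ccc(F)cc2)cc2cc(-c3ccccc3)[nH]c12` carries the change (fluoro in place of hydrogen on an aromatic carbon). For the measured compounds named here, of the single measured step, none concerns a fluoro in place of hydrogen; the only known step concerns a different position and a different group and was itself within the scatter. No measured comparison therefore bears directly on this change, and the shown data give no ground for expecting a step beyond the scatter in either direction in this assay.

Compound 3 is accordingly expected to lie close to compound 2, the estimated step being a number 1.4 percentage points lower from compound 2 to compound 3 (within the scatter). The estimate for compound 3 in this assay is 92%, with a range from 78% to 102%.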

Compound 3, a percentage reported as activity, at one concentration (the size of the read-out at that concentration, not a potency): 72.2%
Compound 3: the middle estimate sits 19.8 percentage points above what was measured; the whole stated range lies above it.
By their numbers in this assay, from the lowest: compound 3; then compounds 2 and 1 (each within the scatter of the next).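

In this assay, among the compounds shown here, the step of a number 21.2 percentage points lower from compound 2 to compound 3 (beyond the scatter) is the first to lie beyond the scatter, and it comes from fluoro in place of hydrogen, para to a large group, on the six-membered aromatic ring of the 2-phenylethenyl group. Against phenyl on the shared core, 2-phenylethenyl alone gave only a number 5.2 percentage points lower from compound 1 to compound 2 (within the scatter), while 2-(4-fluorophenyl)ethenyl gives a number 26.4 percentage points lower from compound 1 to compound 3 (beyond the scatter), so in these three compounds the read-out at this one concentration separates from that of phenyl only once the fluoro is present. No measurement that could account for this step is at hand.

The compounds shown leave open whether the step belongs to fluoro itself or would also follow from chloro, methoxy, an amine or a carboxylic acid on that ring. They also leave open whether fluoro on the phenyl group of compound 1, without the ethenyl link, would move the read-out in the same way, and how the step would look over a range of concentrations.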